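Removing the chloro from compound 1

This account rests on a few compounds, and the source may have more. Where it says the series, first, only, none or still open, it means among the compounds named here.

Among the measured compounds shown here, in a functional assay on HEK293 cells for agonist activity at Neuronal acetylcholine receptor; alpha4/beta2 (Homo sapiens), read by FLIPR and calcium flux (on this read-out lower numbers stand for an effect already at smaller amounts and higher numbers for an effect only at larger amounts of compound), compound 1 `COc1cc(N2CCCNCC2)cnc1Cl` gives 91.2 nM, the second highest of the three numbers so far. Compound 2 `Clc1ncc(N2CCCNCC2)cc1Br` gives 57.5 nM; the step of a 1.6-fold lower number from compound 1 to compound 2 (0.20 log units; within the scatter) lies within the scatter. Compound 3 `Clc1cncc(N2CCNCC2)c1` differs from compound 1 in more than one place. Compound 3 gives 22900 nM, a far higher number than compound 1.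

Compound 4 `COc1cncc(N2CCCNCC2)c1` differs from compound 1 by hydrogen in place of chloro on an aromatic carbon, on the carbon next to the ring nitrogen and ortho to the methoxy group. For the measured compounds named here, no measured step exchanges this chloro for hydrogen. Going by the values given here, the only single-place step, a 1.6-fold lower number from compound 1 to compound 2 (0.20 log units; within the scatter), touches the other substituent and is within the scatter, so it says little about the chloro. Among the compounds with values here, compound 3 shows only that a compound lacking the methoxy and carrying a different amine ring gives a much higher number, and that cannot be laid on the chloro alone. A modest rise in this assay is therefore expected, a 3.3-fold higher number from compound 1 to compound 4 (0.52 log units; beyond the scatter). Compound 4 is expected to give about 300 nM, with a range from 60 nM to 1500 nM.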

Compound 4, half-maximal effective concentration: 1410 nM
The estimate for compound 4 lay 4.7-fold (0.67 log units) below the measured number; the measured number falls inside the stated range.
By their numbers in this assay, from the lowest: compounds 2 and 1 (each within the scatter of the next); then compound 4; then compound 3.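

In this assay the chloro on the aromatic carbon next to the ring nitrogen is not interchangeable with hydrogen: this exchange gives a 15-fold higher number from compound 1 to compound 4 (1.19 log units; beyond the scatter) and lies beyond the scatter. Among the compounds shown here, the only earlier single-place step, a 1.6-fold lower number from compound 1 to compound 2 (0.20 log units; within the scatter) with bromo in place of methoxy, stayed within the scatter, so this is the first change to move the number beyond it, and only one heavy atom leaves. Nothing available explains why this exchange has so large a step.

Going by these compounds, whether fluoro, methyl or a nitrile on this carbon would hold the number near that of compound 1 remains open. Also open, on these data alone, is whether hydrogen in place of chloro gives a step of similar size with bromo in place of methoxy, on the core of compound 2.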